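Swapping cyano for phenylsulfonyl on an aromatic carbon

The source may report more compounds than this note shows. Statements on the series, on what has been measured and on what is new or still open speak of the compounds shown alone.

In a functional assay on the whole organism for inhibition, with Cavia porcellus as the target (on this read-out lower numbers stand for an effect already at smaller amounts and higher numbers for an effect only at larger amounts of compound), compound 1 `CN(C)/C(=N\C#N)C1=CC(C)(C)Oc2ccc([N+](=O)[O-])cc21` gives 51.3 nM, while compound 2 `CN(C)/C(=N\C#N)C1=CC(C)(C)Oc2ccc(C#N)cc21` gives 2140 nM, the higher of these two numbers. For the measured compounds named here, the only measured step, a 42-fold higher number from compound 1 to compound 2 (1.62 log units; beyond the scatter), put cyano in place of nitro and was large. Compound 3 `CN(C)/C(=N\C#N)C1=CC(C)(C)Oc2ccc(S(=O)(=O)c3ccccc3)cc21` changes the same aromatic carbon again: phenylsulfonyl in place of cyano on an aromatic carbon. This single step is thin evidence, but it shows that a swap here can shift the number strongly, with compound 2 at the high end. The expected change is therefore a sizeable drop, a 7.1-fold lower number from compound 2 to compound 3 (0.85 log units; beyond the scatter). For compound 3 the estimated value is 300 nM, within an expected range from 40 nM to 2500 nM.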

Compound 3, half-maximal effective concentration: 3630 nM
Estimate against measurement, compound 3: 12-fold (1.08 log units) below, and the stated range ends below it.
By their numbers in this assay, from the lowest: compound 1; then compounds 2 and 3 (each within the scatter of the next).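

In this assay, phenylsulfonyl in place of cyano on this aromatic carbon gives a 1.7-fold higher number from compound 2 to compound 3 (0.23 log units; within the scatter), so a group carrying a whole extra aromatic ring leaves the number where cyano had it. Phenylsulfonyl in place of nitro gives a 71-fold higher number from compound 1 to compound 3 (1.85 log units; beyond the scatter), which leaves nitro alone at the low end among these three groups. Nothing available here explains why nitro stands apart.

Still open, going by these compounds, is how an amine, a carboxylic acid or a chlorine on this carbon would compare. So is whether any group besides nitro can reach a similarly low number here.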